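The source may report more compounds than this note shows. Statements on the series, on what has been measured and on what is new or still open speak of the compounds shown alone.

Three compounds with a shared core differ in one place: compound 1 `CCOc1cc(OC)ccc1C[S+]([O-])c1ncccc1C(=O)Nc1ccncc1`, compound 2 `COc1ccc(C[S+]([O-])c2ncccc2C(=O)Nc2ccncc2)c(OC)c1` and compound 3 `COc1ccc(C[S+]([O-])c2ncccc2C(=O)Nc2ccncc2)c(OCCF)c1`. In an ADME assay (on this read-out lower numbers stand for a shorter-lived compound and higher numbers for a longer-lived compound), compound 1 gives < 0.02 h, which is a limit of the assay and not a number. Compound 2 gives < 0.02 h, again a limit. Compound 3 gives < 0.02 h, also a limit. Compound 3 therefore has no exact value and stands with the other two: the limit of < 0.02 h in this assay, at which 3 of the 3 values shown sit.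

Compound 4 `COCOc1cc(OC)ccc1C[S+]([O-])c1ncccc1C(=O)Nc1ccncc1` has not yet been measured. Its change from compound 3 is methoxy in place of fluoromethyl on a saturated chain carbon bound to an oxygen on an aromatic ring, turning 2-fluoroethoxy into methoxymethoxy.

The measured changes at this place are a step that the two limits leave unreadable from compound 1 to compound 2, a step that the two limits leave unreadable from compound 1 to compound 3 and a step that the two limits leave unreadable from compound 2 to compound 3, so none offers a size to carry over. With no readable step to build on, no shift beyond the scatter is expected, and the expected step is a step that the limit leaves unreadable from compound 3 to compound 4. Compound 4 is estimated at 0.015 h, with an expected range of 0.005 h to 0.04 h.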

Compound 4, half-life: < 0.02 h
Compound 4 ended at the assay's limit; the forecaster's own chance of this, stated with the estimate: 85%; the middle value does not contradict the limit.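

Among these compounds, compound 4, like compounds 1, 2 and 3, gives only a limit and not a number, so no step to compound 4 can be read in this assay: the limit of < 0.02 h in this assay, at which 4 of the 4 values shown sit. The compounds shown leave open how these four compare, and whether any group at this place gives a readable half-life.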